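This account rests on a few compounds, and the source may have more. Where it says the series, first, only, none or still open, it means among the compounds named here.

Measured compounds in an ADME assay on HEp-2 cells (Homo sapiens) for cytotoxicity, read by CCK-8 assay, with a stated time of 6 days; on this read-out higher numbers stand for lower toxicity in this test and lower numbers for higher toxicity in this test:
Compound 1 `NCCNc1cc(N2CCN(C(=O)C3(c4ccccc4)CCCC3)CC2)nc2ccccc12` gives > 100000 nM, a limit of the test.
Compound 2 `CC(C)CC(=O)N1CCN(c2cc(NCCN)c3ccccc3n2)CC1` gives > 100000 nM, a limit of the test.
Compound 3 `NCCNc1cc(N2CCN(C(=O)C3(c4ccccc4)CC3)CC2)nc2ccccc12` gives > 100000 nM, a limit of the test.

Compound 3 thus stands only at a limit in this assay, not at a number, and all three values sit at the same point, as the limit of > 100000 nM in this assay, at which 3 of the 3 values shown sit, records. The change to compound 4 `CC(C)C(=O)N1CCN(c2cc(NCCN)c3ccccc3n2)CC1` is isopropyl in place of 1-phenylcyclopropyl on a carbonyl carbon. The measured steps that bear on it, a step that the two limits leave unreadable from compound 1 to compound 3 and a step that the two limits leave unreadable from compound 2 to compound 3, together with a step that the two limits leave unreadable from compound 1 to compound 2, run between limits only, so no size can be read from them. For compound 4 the expected step is a step that the limit leaves unreadable from compound 3 to compound 4. Compound 4 is estimated at 150000 nM, with a range from 60000 nM to 400000 nM, most likely again reported only as a limit.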

Compound 4, half-maximal cytotoxic concentration: > 100000 nM
Compound 4 gave a limit, no number; the forecaster's own chance of this, stated with the estimate: 90%; the middle value is on the limit's open side.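

In this assay, going by these compounds alone, compound 4 gives > 100000 nM, a limit, so no step to compound 4 from compound 1, compound 2 or compound 3 can be read. Whether the group on the carbonyl carbon changes toxicity in this test at all stays open, since every value sits at one point: the limit of > 100000 nM in this assay, at which 4 of the 4 values shown sit.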